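The compounds below may be only part of what the source reports. "The series", "measured", "known", "first", "only" and "open" are said of these compounds alone.

Of the compounds shown here, three sharing one core have been measured in a functional assay (Pituitary gland cell) with Rattus norvegicus as the target; on this read-out lower numbers stand for an effect already at smaller amounts and higher numbers for an effect only at larger amounts of compound. Compound 1 `CC(O)Cn1nnc(-c2ccccc2-c2ccc(CN3C(=O)[C@H](NC(=O)CC(C)(C)N)CCc4ccccc43)cc2)n1` gives 0.05 uM, compound 2 `Cn1nnnc1-c1ccccc1-c1ccc(CN2C(=O)[C@H](NC(=O)CC(C)(C)N)CCc3ccccc32)cc1` gives 0.5 uM, and compound 3 `COC(=O)c1ccccc1-c1ccc(CN2C(=O)[C@H](NC(=O)CC(C)(C)N)CCc3ccccc32)cc1` gives 2 uM, the highest number of the three. Compound 4 `CC(C)(N)CC(=O)N[C@@H]1CCc2ccccc2N(Cc2ccc(-c3ccccc3-c3nnnn3CC(=O)O)cc2)C1=O` differs from compound 3 in one place: 1-(carboxymethyl)-1H-tetrazol-5-yl in place of methoxycarbonyl on an aromatic carbon. Among the compounds with values here, two measured steps bear on this, each trading a tetrazole for methoxycarbonyl: a 4.0-fold higher number from compound 2 to compound 3 (0.60 log units; beyond the scatter) and a 40-fold higher number from compound 1 to compound 3 (1.60 log units; beyond the scatter). Since compound 4 again carries a tetrazole, much as compound 2 does, a lower number is expected, likely closer to the smaller of those two steps. The estimated step for compound 4 is a 6.7-fold lower number from compound 3 to compound 4 (0.82 log units; beyond the scatter). Compound 4 is therefore expected near 0.3 uM, within a range from 0.05 uM to 2 uM.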

Compound 4, concentration for half-maximal effect: 1 uM
Compound 4: the middle estimate sits 3.3-fold (0.52 log units) below what was measured, and the stated range covers the measured number.
By their numbers in this assay, from the lowest: compound 1; then compounds 2, 4 and 3 (each within the scatter of the next, the first and the last beyond it).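

Swapping methoxycarbonyl for 1-(carboxymethyl)-1H-tetrazol-5-yl makes no readable difference (a 2.0-fold lower number from compound 3 to compound 4 (0.30 log units; within the scatter)), so a tetrazole at this position does not by itself set a compound apart from the ester. Placing carboxy on the methyl chain of compound 2 also stays within the scatter (a 2.0-fold higher number from compound 2 to compound 4 (0.30 log units; within the scatter)). Only the 2-(2-hydroxypropyl)-2H-tetrazol-5-yl group of compound 1 stands apart (a 20-fold higher number from compound 1 to compound 4 (1.30 log units; beyond the scatter)). Nothing shown explains this. On these data alone, a 1-(2-hydroxypropyl)-1H-tetrazol-5-yl group would separate the chain's effect from that of its attachment point, and a carboxylic acid directly on the aromatic carbon remains open too.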